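Moving the methyl on the phenyl ring of compound 2

The source may hold more compounds than are shown below. What is called first, only, known or untested is meant among the compounds shown, and "the series" means these compounds.

Measured in a functional assay on T47D cells (Homo sapiens) for antiproliferative activity, read by MTT assay, with a stated time of 72 h; a higher number here means a weaker inhibitor, a lower number a stronger inhibitor:
Compound 1 `CCCCn1ccnc1-c1cc(OC)c(OC)c(OC)c1`: > 100000 nM (a limit)
Compound 2 `COc1cc(-c2nccn2-c2ccc(C)cc2)cc(OC)c1OC`: 20500 nM

For the measured compounds named here, compound 2 holds the only true number here, 20500 nM, in this assay. The entry for compound 1 is only a limit, > 100000 nM, and not a number. Compound 3 `COc1cc(-c2nccn2-c2cccc(C)c2)cc(OC)c1OC` carries 3-methylphenyl in place of 4-methylphenyl on an aromatic nitrogen. Going by the values given here, the one measured step, an at least 4.8-fold lower number from compound 1 to compound 2 (0.68 log units; beyond the scatter), is bounded by the limit of > 100000 nM in this assay, at which 1 of the 2 values shown sits, and exchanged butyl for 4-methylphenyl. It does not shift the methyl, so no step beyond the scatter is expected, in either direction. The expected change is a 1.1-fold lower number from compound 2 to compound 3 (0.06 log units; within the scatter), with little weight on its direction. Compound 3 is estimated at 18000 nM, within an expected range of 5000 nM to 70000 nM.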

Compound 3, half-maximal inhibitory concentration: 29300 nM
Compound 3: the middle estimate sits 1.6-fold (0.21 log units) below what was measured; the range from low to high includes it.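

In this assay, moving the methyl gives a 1.4-fold higher number from compound 2 to compound 3 (0.16 log units; within the scatter), so the 4-methylphenyl and 3-methylphenyl groups on this aromatic nitrogen cannot be told apart here. The gain over butyl also holds with the methyl moved, with an at least 3.4-fold lower number from compound 1 to compound 3 (0.53 log units; beyond the scatter). Compound 1 gives only a limit and not a number, so that step has no exact size: the limit of > 100000 nM in this assay, at which 1 of the 3 values shown sits.

The compounds shown leave open whether a methoxy group, a chlorine atom or an amine in place of the methyl on the phenyl ring would shift the number beyond the scatter.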